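This account rests on a few compounds, and the source may have more. Where it says the series, first, only, none or still open, it means among the compounds named here.

Working notes on the series. Compound 2 `Cc1ccc(C(C)C)cc1OC(=O)NC1CCCC1` carries a cyclopentyl on the amide-type nitrogen; in a toxicity assay on the whole organism (H4IIE cells) for cytotoxicity, with Rattus norvegicus as the target, read by MTT assay, with a stated time of 24 h, tested at 2.5 uM (a lower number here means a stronger effect, a higher number a weaker effect of the compound at the concentration tested), compound 2 gives 47.8%. For the measured compounds named here, the only other compound measured is compound 1 `Cc1ccc(C(C)C)c(OC(=O)Nc2ccc([N+](=O)[O-])cc2)c1`, which in this assay gives 40%; the number of compound 2 and that of compound 1 lie within the usual scatter of each other, so the two cannot be separated on these data, and compound 2 simply stands alongside compound 1 at the upper part of the narrow spread seen so far.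

Compound 3 `Cc1ccc(C(C)C)cc1OC(=O)Nc1cccc(F)c1` is not yet measured. It differs from compound 2 in one place, (3-fluorophenyl in place of cyclopentyl on an amide-type nitrogen). Going by the values given here, no step between measured compounds covers this change; compound 1 is the only aromatic example in the set, and its group is a different one, so it serves as no more than a loose pointer. The step from compound 2 to compound 3 in this assay is expected to be a number 5.8 percentage points lower from compound 2 to compound 3 (within the scatter), downward by a small amount that need not reach beyond the scatter. Compound 3 is estimated to give 42% in this assay, with a range from 28% to 58%.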

Compound 3, a percentage reported as activity, at one concentration (the size of the read-out at that concentration, not a potency): 45.8%
Compound 3: the middle estimate sits 3.8 percentage points below what was measured; low and high end bracket the measured number.
By their numbers in this assay, from the lowest: compounds 1, 3 and 2 (each within the scatter of the next).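

In this assay, for the compounds shown here, the exchange of cyclopentyl for 3-fluorophenyl on an amide-type nitrogen gives a number 2 percentage points lower from compound 2 to compound 3 (within the scatter) and provides the first reading of a change in one place. At this position, a five-membered non-aromatic ring of carbon only and a six-membered aromatic ring of carbon only bearing fluorine therefore cannot be told apart at the single concentration tested, something the pair of compound 1 and compound 2, which differ in more than one place, could not show. Nothing at hand bears on what lies behind this result.

Still open, going by these compounds, is whether an unsubstituted phenyl, a longer chain such as n-hexyl, or a phenyl carrying an amine or a carboxylic acid would, in place of the 3-fluorophenyl of compound 3, give a number beyond the scatter. Also open, on these data alone, is whether the near-equal numbers of compound 2 and compound 3 at the single concentration tested would hold at other concentrations.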